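Chain extension of hydroxamate linkers on two heteroaryl cores

This account rests on a few compounds, and the source may have more. Where it says the series, first, only, none or still open, it means among the compounds named here.

Compound 2 `Nc1ncnc2c1c(-c1cnc3[nH]ccc3c1)nn2CCCCCC(=O)NO` and compound 1 `Nc1ncnc2c1c(-c1cnc3[nH]ccc3c1)nn2CCCCCCCCC(=O)NO` share a core and differ by 3-(hydroxycarbamoyl)propyl in place of hydroxycarbamoyl on a saturated chain carbon, five bonds along the chain from an aromatic nitrogen. In a functional assay on Hep 3B2 cells (Homo sapiens) for inhibition, read by MTT assay, with a stated time of 72 h (a higher number here means a weaker inhibitor, a lower number a stronger inhibitor), compound 2 gives only a limit, > 50000 nM, which is the limit of > 50000 nM in this assay, at which 1 of the 3 values shown sits. Compound 1 gives 8390 nM in this assay, so the step is an at least 5.9-fold lower number from compound 2 to compound 1 (0.77 log units; beyond the scatter). Compound 3 `Nc1nc2cc(-c3nn(CCCCCC(=O)NO)c4ncnc(N)c34)ccc2o1` carries a different core; the difference between the two cores is not broken down here. In this assay compound 3 gives 34200 nM. Compound 4 `Nc1nc2cc(-c3nn(CCCCCCCCC(=O)NO)c4ncnc(N)c34)ccc2o1` differs from compound 3 by 3-(hydroxycarbamoyl)propyl in place of hydroxycarbamoyl on a saturated chain carbon, five bonds along the chain from an aromatic nitrogen, the same change seen from compound 2 to compound 1. It is expected that compound 4 will show a step of about a 5.7-fold lower number from compound 3 to compound 4 (0.76 log units; beyond the scatter) in this assay, because the earlier step was an at least 5.9-fold lower number from compound 2 to compound 1 (0.77 log units; beyond the scatter). Compound 4 is therefore estimated at 6000 nM, with a range from 1500 nM to 25000 nM.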

Compound 4, half-maximal inhibitory concentration: 8890 nM
Compound 4: middle estimate off by 1.5-fold (0.17 log units), on the low side, within the range that was stated.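

In this assay, the longer chain again gives a lower number on the second core, a 3.8-fold lower number from compound 3 to compound 4 (0.59 log units; beyond the scatter), so the direction of the change carries over from one core to the other. Whether the size of the step also carries over cannot be settled: the same change on two cores in this assay, an at least 5.9-fold lower number (0.77 log units; beyond the scatter) from compound 2 to compound 1 and a 3.8-fold lower number (0.59 log units; beyond the scatter) from compound 3 to compound 4; the limit leaves it open whether they differ. With the longer chain in place, the two cores cannot be told apart, a 1.1-fold higher number from compound 1 to compound 4 (0.03 log units; within the scatter), but two cores and one pair of chain lengths show nothing about how the change behaves on any other core.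

The compounds shown leave open whether a chain of intermediate length already lowers the number, or whether a chain longer than that of compound 4 lowers it further. They also leave open what a carboxylic acid in place of hydroxycarbamoyl would give.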